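Removing the (dimethylamino)methyl group from compound 3

This account rests on a few compounds, and the source may have more. Where it says the series, first, only, none or still open, it means among the compounds named here.

Compound 1 `Cn1nccc1-c1cnc(NCc2c(F)ccc3c2CCO3)c2cn[nH]c(=O)c12`: 2.6
Compound 2 `Cc1ncccc1-c1cnc(NCc2c(F)ccc3c2CCO3)c2n[nH]c(=O)n12`: 2.5
Compound 3 `CN(C)Cc1ccc(C(=O)Nc2cnc(NCc3c(F)ccc4c3CCO4)n3cnnc23)cc1`: 1.8

All three compounds were measured in a physicochemical assay for lipophilicity, using the shake flask method, in phosphate buffer, measured as octanol-water partition, with a stated time of 30 min, at pH 7.4; a lower number here means a more polar compound, a higher number a more lipophilic compound. Compound 3 stands lowest of the three at 1.8, and the gap to each of the other two lies beyond the scatter. Compound 4 `O=C(Nc1cnc(NCc2c(F)ccc3c2CCO3)n2cnnc12)c1ccccc1` has not yet been measured in this assay. It differs from compound 3 in one place: hydrogen in place of (dimethylamino)methyl on an aromatic carbon. In words, hydrogen stands in place of (dimethylamino)methyl on an aromatic carbon. Among the measured compounds shown here, no pair of measured compounds shows this change, so the expectation rests on little direct evidence. For the measured compounds named here, the only guide is that compound 1 gives 2.6 and compound 2 gives 2.5, and compound 4 is expected to land near these values rather than near compound 3. The estimated change is a number 0.90 log units higher from compound 3 to compound 4 (beyond the scatter), an upward step expected to lie beyond the scatter. For compound 4 the expected value is 2.7, with an estimated range of 2.2 to 3.2.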

Compound 4, distribution coefficient: 3
The estimate for compound 4 lay 0.30 log units below the measured number, and the stated range covers the measured number.
By their numbers in this assay, from the lowest: compound 3; then compounds 2 and 1 (each within the scatter of the next); then compound 4.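

Among the compounds shown here, this is the first comparison in which only one place changes: in this assay, putting hydrogen in place of (dimethylamino)methyl on an aromatic carbon, para to a large group, gives a number 1.20 log units higher from compound 3 to compound 4 (beyond the scatter) and this step is large. The change at this single position, 4-((dimethylamino)methyl)phenyl to phenyl, thus moves the number well beyond the scatter while the rest of the molecule stays the same. No measurement shown here accounts for the size of this step.

Going by these compounds, what a methoxy group, a carboxylic acid or a morpholine on a longer chain would give at this same position remains open. So does whether a step of this size would recur on the different cores of compound 1 and compound 2.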